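The compounds below may be only part of what the source reports. "The series", "measured", "known", "first", "only" and "open" are said of these compounds alone.

Among the compounds with values here, compound 1 `c1ccc2nc(COc3ccc(OCCCc4nnn[nH]4)cc3)ccc2c1` is one of three compounds measured in a functional assay (lung) for inhibition, with Cavia porcellus as the target; a higher number here means a weaker inhibitor, a lower number a stronger inhibitor. In this assay compound 1 gives 250 nM, the highest of the three numbers. Compound 3 `CC(CCCc1nnn[nH]1)c1ccc(OCc2ccc3ccccc3n2)cc1` gives 170 nM in this assay, a number that lies within the usual scatter of the number for compound 1, so the two cannot be told apart. Compound 2 `c1ccc(C(CCc2nnn[nH]2)Cc2ccc(OCc3ccc4ccccc4n3)cc2)cc1` gives 14 nM in this assay, a number that lies well beyond the scatter below that of compound 1, so compound 2 is the stronger inhibitor of that pair.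

Compound 4 `O=C(O)CCCCc1ccc(OCc2ccc3ccccc3n2)cc1` has not yet been measured. It comes from compound 1 by a single change (4-carboxybutyl in place of 3-(1H-tetrazol-5-yl)propoxy on an aromatic carbon). The 4-carboxybutyl enters on an aromatic carbon of a six-membered aromatic ring of carbon only, para to a large group, where the 3-(1H-tetrazol-5-yl)propoxy stood. Within the data shown here, no pair of measured compounds shows this kind of change, so there is no measured example to lean on.

The step expected in this assay is a 2.0-fold higher number from compound 1 to compound 4 (0.30 log units; within the scatter), modest and toward a weaker inhibitor, and it may not reach beyond the scatter. Compound 4 is therefore expected to give about 500 nM in this assay, with a likely range from 120 nM to 2500 nM.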

Compound 4, half-maximal inhibitory concentration: 450 nM
Beside the measured number, compound 4's estimate is 1.1-fold (0.05 log units) above it; low and high end bracket the measured number.
By their numbers in this assay, from the lowest: compound 2; then compounds 3, 1 and 4 (each within the scatter of the next, the first and the last beyond it).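

Placing 4-carboxybutyl where the 3-(1H-tetrazol-5-yl)propoxy stood, on an aromatic carbon para to a large group, gives a 1.8-fold higher number from compound 1 to compound 4 (0.26 log units; within the scatter) in this assay and so leaves the two compounds indistinguishable. Compounds 1, 2 and 3 all end in the same tetrazole ring, so they could not show whether inhibition in this range depends on that ring; compound 4 shows that, on the core of compound 1, an open chain ending in a carboxylic acid can take its place without a change that stands clear of the scatter. No measurement shown here accounts for this similarity between the two groups.

The swap changes the end group and also removes the oxygen that links the chain to the aromatic ring, so the contribution of each change remains unresolved; a 3-carboxypropoxy group or a 4-(1H-tetrazol-5-yl)butyl group would change only one of them. Also open, as far as these compounds go, is how other end groups, such as a primary amide or a sulfonamide, or a longer chain would fare at this position.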